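The compounds below may be only part of what the source reports. "The series", "measured", "known", "first", "only" and "open" are said of these compounds alone.

Measured in an ADME assay on liver for metabolic stability, with Liver microsome (Homo sapiens) as the target, using microsomes, with a stated time of 10 min, tested at 0.5 uM; a lower number here means that less of the compound is left, a higher number that more of the compound is left:
- Compound 1 `Cc1ccncc1-c1cccc2c1cnn2-c1nccs1`: 69%
- Compound 2 `Cc1ccncc1-c1cccc2c1ncn2-c1cnccn1`: 98%

Compound 2 has the higher of the two numbers, and the gap to compound 1 is beyond the usual scatter. Compound 3 `Cc1ccncc1-c1cccc2c1ncn2-c1cscn1` keeps the core of compound 2 but has 1,3-thiazol-4-yl in place of pyrazin-2-yl on an aromatic nitrogen. Among the compounds with values here, no measured pair differs in only one place, so direct guidance is missing. Compound 2 at 98% leaves little room to rise, so a fall is expected in this assay. The estimated change, a number 14 percentage points lower from compound 2 to compound 3 (beyond the scatter), is a moderate fall, slightly beyond the scatter. For compound 3 the expected value is 84%, with an estimated range of 65% to 100%.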

Compound 3, percent of the compound remaining: 90%
Compound 3: the middle estimate sits 6 percentage points below what was measured, within the range that was stated.
By their numbers in this assay, from the lowest: compound 1; then compounds 3 and 2 (each within the scatter of the next).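

In this assay, within the data shown here, the first pair that differs in one place gives a number 8 percentage points lower from compound 2 to compound 3 (within the scatter), with 1,3-thiazol-4-yl in place of pyrazin-2-yl on the aromatic nitrogen. At this position, then, a five-membered aromatic ring holding sulfur can stand in for a six-membered aromatic ring with no difference beyond the scatter. No supporting measurement speaks to the reason for this result. Going by these compounds, both groups are aromatic rings, so it remains open how an open-chain amine, a carboxylic acid or a longer alkyl chain on this nitrogen would read in this assay. On these data alone, it also remains open whether this exchange would behave the same way on the core of compound 1.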